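From 4-methoxybenzyl to methyl on the shared core

This account rests on a few compounds, and the source may have more. Where it says the series, first, only, none or still open, it means among the compounds named here.

Compound 1 (`COc1ccc(Cn2nc(Nc3cc(C)[nH]n3)c3ccccc3c2=O)cc1`) gives > 30000 nM in a functional assay on MCF7 cells (Homo sapiens) for cytotoxicity (on this read-out higher numbers stand for weaker inhibition and lower numbers for stronger inhibition), which is a limit of the assay and not a number. Compound 1 therefore sits at the limit of > 30000 nM in this assay, at which 1 of the 2 values shown sits. Compound 2 (`Cc1cc(Nc2nn(Cc3ccc(S(C)(=O)=O)cc3)c(=O)c3ccccc23)n[nH]1`) gives a true reading of 4500 nM. Going by the values given here, the only measured step, an at least 6.6-fold lower number from compound 1 to compound 2 (0.82 log units; beyond the scatter), came with methylsulfonyl in place of methoxy on an aromatic carbon. Compound 3 (`Cc1cc(Nc2nn(C)c(=O)c3ccccc23)n[nH]1`) goes further, with hydrogen in place of 4-methoxyphenyl on a saturated chain carbon bound to an aromatic nitrogen. Among the compounds with values here, no measured step removes that ring, so the evidence is indirect. Within the data shown here, compound 2 shows only that a change on the ring can matter, and at 4500 nM it still carries the ring. No shift beyond the scatter is therefore expected in this assay. The expected step is a number no higher from compound 1 to compound 3 (the limit leaves the size open). Compound 3 is estimated at 30000 nM, with an expected range of 9000 nM to 60000 nM.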

Compound 3, half-maximal inhibitory concentration: > 30000 nM
Compound 3: no number, only a limit; the forecaster's own chance of this, stated with the estimate: 60%; the middle value sits exactly at the limit.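

In this assay compound 3 gives > 30000 nM, which is a limit of the assay and not a number. Compound 1 also holds only a limit, and the step between the two cannot be read. The compounds shown leave open whether 4-methoxybenzyl to methyl changes the reading at all.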